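Bulk on the amide side chain and maximal response

The source may hold more compounds than are shown below. What is called first, only, known or untested is meant among the compounds shown, and "the series" means these compounds.

Compound 2 `CCCNC(=O)c1ccc(C#Cc2cccc(F)c2)cn1` gives 8.3% in an ADME assay on HEK293 cells for agonist activity at metabotropic glutamate receptor 5 (Rattus norvegicus), read by fluorescence and calcium flux (on this read-out lower numbers stand for smaller maximal responses and higher numbers for larger maximal responses), the lower of the two measured values. Compound 1 `CC(C)[C@@H](C)NC(=O)c1ccc(C#Cc2cccc(F)c2)cn1` gives 22.5%, and the step of a number 14.2 percentage points lower from compound 1 to compound 2 (beyond the scatter) shows that trimming the branched group to a plain chain lowered the response. Compound 3 `O=C(NCC1CCC1)c1ccc(C#Cc2cccc(F)c2)cn1` carries cyclobutyl in place of ethyl on a saturated chain carbon bound to an amide-type nitrogen. Among the measured compounds shown here, only that one step bears on this change, and it points in the reverse direction, so a modest rise in this assay is expected for compound 3, a number 9.7 percentage points higher from compound 2 to compound 3 (within the scatter). For compound 3 a value of 18% is estimated, within 5% to 35%.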

Compound 3, largest response reached (reported as efficacy), in percent of the reference or control that the assay uses: 4.7%
The estimate for compound 3 lay 13.3 percentage points above the measured number; measured number below the stated range.
By their numbers in this assay, from the lowest: compounds 3 and 2 (each within the scatter of the next); then compound 1.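

In this assay, cyclobutyl in place of ethyl reads as a number 3.6 percentage points lower from compound 2 to compound 3 (within the scatter), so this larger ring-bearing group gives no response distinct from the plain propyl chain. Cyclobutylmethyl in place of 1,2-dimethylpropyl reads as a number 17.8 percentage points lower from compound 1 to compound 3 (beyond the scatter), which leaves compound 1 apart from the other two compounds. No measurement here explains this difference. Going by these compounds, what remains open is whether the higher response in compound 1 is tied to the branched shape of its side chain, and how a tert-butyl group or a longer chain such as hexyl on the amide-type nitrogen would compare.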